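Trifluoromethyl removal on the aryl thiazole hydrazones

This account rests on a few compounds, and the source may have more. Where it says the series, first, only, none or still open, it means among the compounds named here.

Measured compounds:
compound 1 `Fc1ccc(/C=N/Nc2nc(-c3ccc(C(F)(F)F)cc3)cs2)cc1F`, 2610 nM
compound 2 `Fc1ccc(/C=N/Nc2nc(-c3ccccc3)cs2)cc1F`, 91400 nM
compound 3 `COc1cc(/C=N/Nc2nc(-c3ccc(C(F)(F)F)cc3)cs2)cc(Br)c1OC`, 18300 nM

In a functional assay on A549 cells (Homo sapiens) for inhibition, read by MTT assay, with a stated time of 48 h (a higher number here means a weaker inhibitor, a lower number a stronger inhibitor), compound 1 gives 2610 nM, the lowest number of the three. The step of a 35-fold higher number from compound 1 to compound 2 (1.54 log units; beyond the scatter) is the change (hydrogen in place of trifluoromethyl on an aromatic carbon). Compound 3 sits second highest; its number is beyond the scatter from both compound 1 and compound 2. The difference between the core of compound 3 and the core of compound 1 is not broken down here.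

Compound 4 `COc1cc(/C=N/Nc2nc(-c3ccccc3)cs2)cc(Br)c1OC` is not yet measured in this assay. Its relation to compound 3 is hydrogen in place of trifluoromethyl on an aromatic carbon, the same change as that from compound 1 to compound 2, at the same place. Among the compounds with values here, the only precedent is a single pair, so the expected step is taken from it but widened. For compound 4 the step of a 19-fold higher number from compound 3 to compound 4 (1.28 log units; beyond the scatter) is expected. This rests on a 35-fold higher number from compound 1 to compound 2 (1.54 log units; beyond the scatter), applied to the number that compound 3 gives, 18300 nM. Compound 4 is therefore estimated at 350000 nM, with a range from 70000 nM to 1500000 nM, and a real chance that only a limit is reported.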

Compound 4, half-maximal inhibitory concentration: 40000 nM
Compound 4: the middle estimate sits 8.8-fold (0.94 log units) above what was measured; measured number below the stated range.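

Replacing trifluoromethyl with hydrogen gives a higher number in this assay on both cores, but the size of the step does not carry over, the new step being a 2.2-fold higher number from compound 3 to compound 4 (0.34 log units; beyond the scatter). The two steps differ clearly: the same change on two cores in this assay, a 35-fold higher number (1.54 log units; beyond the scatter) from compound 1 to compound 2 and a 2.2-fold higher number (0.34 log units; beyond the scatter) from compound 3 to compound 4, 16-fold (1.20 log units) apart, beyond the scatter of two such steps. The direction therefore holds in these two pairs while the size does not transfer from one core to the other; the pairs do not show which feature of the cores accounts for the gap, and they set no rule for any further core.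

The compounds shown leave open whether another group in place of trifluoromethyl, such as an amine or a carboxylic acid, would shift the number on either core. They also leave unresolved how the separate differences between the core of compound 1 and the core of compound 3 contribute, as no compounds shown change those places one at a time.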